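From 2-Fluorophenyl to 4-Fluorophenyl on Compound 1

The compounds below may be only part of what the source reports. "The series", "measured", "known", "first", "only" and "open" are said of these compounds alone.

Of the compounds shown here, three have so far been measured in a physicochemical assay for lipophilicity, read by HPLC, at pH 7.5; on this read-out higher numbers stand for higher lipophilicity and lower numbers for lower lipophilicity. Compound 1 (`CC[C@@H](Nc1c(C#N)c(-c2ccc(-c3ccccc3F)cc2)nc2cnccc12)C(N)=O`) gives 2.7, the highest of the three numbers. Compound 2 (`CC[C@H](Nc1c(C#N)c(-c2ccc(Br)cc2)nc2cnccc12)C(N)=O`) gives 2.3 and compound 3 (`CCOc1ccccc1-c1ccc(-c2nc3cnccc3c(N[C@H](CC)C(=O)NS(=O)(=O)C3CC3)c2C#N)cc1`) gives 2.3. Both of these lie lower than compound 1 by more than the usual scatter of repeated measurements, and they show the same number as each other.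

Compound 4 (`CC[C@@H](Nc1c(C#N)c(-c2ccc(-c3ccc(F)cc3)cc2)nc2cnccc12)C(N)=O`) has not yet been measured. It has the same atoms as compound 1, joined differently: 4-fluorophenyl in place of 2-fluorophenyl on an aromatic carbon. A 4-fluorophenyl stands in place of a 2-fluorophenyl on an aromatic carbon, para to a large group, and the rest of the structure is unchanged.

Among the compounds with values here, neither compound 2 nor compound 3 differs from compound 1 in only one place, so the measured compounds offer no direct precedent for this swap. The expectation therefore rests on compound 1 itself, at 2.7, and on the matching counts of the two fluorophenyl groups. The expected change is a number 0.10 log units higher from compound 1 to compound 4 (within the scatter), slightly upward and not beyond the scatter. For compound 4 the estimated value in this assay is 2.8, with an expected range from 2.4 to 3.2.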

Compound 4, distribution coefficient: 2.7
For compound 4 the middle estimate is 0.10 log units above the measured one; measured number inside the range.
By their numbers in this assay, from the lowest: compounds 2 and 3 (each within the scatter of the next); then compounds 1 and 4 (each within the scatter of the next).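

In this assay, putting 4-fluorophenyl in place of 2-fluorophenyl on an aromatic carbon, para to a large group, gives no change at the digits printed from compound 1 to compound 4 (within the scatter). Within the data shown here, this is the first step in the set that changes a single place, which neither compound 2 nor compound 3 could offer when set against compound 1, and on this read-out it leaves the two fluorophenyl groups indistinguishable at this position. Nothing in the data explains this outcome, so it stands as an observation only.

The compounds shown compare only these two fluorophenyl groups at this position, so they leave open whether a different group there, such as an amine, a carboxylic acid or a longer alkyl chain, would give a step beyond the scatter. They also leave open whether the same swap would read the same way in a compound with a different group on the rest of the structure, since this single step comes from the core of compound 1 alone.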